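This account rests on a few compounds, and the source may have more. Where it says the series, first, only, none or still open, it means among the compounds named here.

Among the three compounds measured so far in a functional assay on CCRF-CEM cells (Homo sapiens) for cytotoxicity, with a stated time of 72 h (a lower number here means a stronger inhibitor, a higher number a weaker inhibitor), compound 3 `O=C1/C(=C/c2ccc(F)cc2)CCC/C1=C\c1cccc([N+](=O)[O-])c1` stands lowest, giving 5050 nM. Its nearest neighbour is compound 1 `O=C1/C(=C/c2ccccc2)CCC/C1=C\c1ccc([N+](=O)[O-])cc1`, which in this assay gives 9320 nM, a gap that lies within the scatter of repeated measurements. The furthest is compound 2 `O=C1/C(=C/c2ccc(F)cc2)CCC/C1=C\c1ccc([N+](=O)[O-])cc1`, which gives 18600 nM, a gap that lies beyond the scatter.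

Compound 4 `O=C1/C(=C/c2ccccc2)CCC/C1=C\c1cccc([N+](=O)[O-])c1` is the next compound to be tested. It differs from compound 3 in one place: hydrogen in place of fluoro on an aromatic carbon. Within the data shown here, only one measured step bears directly on this change, and it runs in the opposite direction: a 2.0-fold higher number from compound 1 to compound 2 (0.30 log units; within the scatter). That step was within the scatter, so the same exchange read backwards, from a fluoro to a hydrogen on the aromatic carbon, gives no firm ground for a step of any size beyond the scatter. If anything, the direction of that one step hints at a slightly lower number for compound 4, but it cannot be relied on.

The step from compound 3 to compound 4 is therefore expected to be small, a 1.4-fold lower number from compound 3 to compound 4 (0.16 log units; within the scatter). Compound 4 is estimated to give 3500 nM in this assay, with a range from 1300 nM to 9500 nM.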

Compound 4, half-maximal inhibitory concentration: 2290 nM
Compound 4: the middle estimate sits 1.5-fold (0.18 log units) above what was measured; the range from low to high includes it.
By their numbers in this assay, from the lowest: compound 4; then compounds 3, 1 and 2 (each within the scatter of the next, the first and the last beyond it).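

Hydrogen in place of fluoro gives a 2.2-fold lower number from compound 3 to compound 4 (0.34 log units; beyond the scatter) in this assay, a modest change, but it gives the exchange of 4-fluorophenyl for phenyl a step beyond the scatter, which the single earlier step, lying within it, could not provide. That earlier step now gains weight, since the change runs the same way and by nearly the same size on two cores, with the fluoro compound giving the higher number in each pair: the same change on two cores in this assay, a 2.0-fold higher number (0.30 log units; within the scatter) from compound 1 to compound 2 and a 2.2-fold higher number (0.34 log units; beyond the scatter) from compound 4 to compound 3, 1.1-fold (0.04 log units) apart, within the scatter of two such steps. Across these two pairs, which are the only ones that carry this change, phenyl gives the lower number and neither pair goes against it, so the effect of the fluoro does not appear to depend on which of the two cores carries it.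

The compounds shown leave open whether a group other than fluoro at this place, such as chloro, methoxy or an amine, would move the number in the same way. They also leave open whether the step survives when the nitro group gives way to a nitrile or a carboxylic acid, and what lies behind the shared step cannot be told from these numbers.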